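Series notes: methyl in place of acid hydrogen on compound 3

The source may report more compounds than this note shows. Statements on the series, on what has been measured and on what is new or still open speak of the compounds shown alone.

Measured compounds:
- compound 1, `CSCC[C@H](NC(=O)c1ccc(NCc2cncn2Cc2cccc(Cl)c2)cc1-c1ccccc1)C(=O)O`: > 10 uM
- compound 2, `CSCC[C@H](NC(=O)c1ccc(NCc2cncn2Cc2ccccc2Cl)cc1-c1ccccc1)C(=O)O`: > 10 uM
- compound 3, `CSCC[C@H](NC(=O)c1ccc(NCc2cncn2Cc2ccc([N+](=O)[O-])cc2)cc1-c1ccccc1)C(=O)O`: > 10 uM

In a functional assay on NIH3T3 cells (Mus musculus) (a higher number here means that more compound is needed for the effect, a lower number that less compound is needed), compound 1 returns only a limit of the assay, > 10 uM. In this assay compound 2 likewise returns only a limit, > 10 uM. Compound 3 stands at a limit as well, > 10 uM; none of the three gives a number. Accordingly the steps a step that the two limits leave unreadable from compound 1 to compound 2, a step that the two limits leave unreadable from compound 1 to compound 3 and a step that the two limits leave unreadable from compound 2 to compound 3 cannot be sized, since (the limit of > 10 uM in this assay, at which 3 of the 3 values shown sit).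

Compound 4, `COC(=O)[C@H](CCSC)NC(=O)c1ccc(NCc2cncn2Cc2ccc([N+](=O)[O-])cc2)cc1-c1ccccc1`, differs from compound 3 by methyl in place of hydrogen on an oxygen next to a carbonyl group. Within the data shown here, no measured step touches this position, so nothing sizes the change; the only bearing is that every measured value sits at the limit. The step from compound 3 to compound 4 is expected to be a step that the limit leaves unreadable from compound 3 to compound 4, which is to say no reliable movement can be predicted. Compound 4 is expected at 15 uM in this assay, with a range from 4 uM to 60 uM, and most likely it too is reported only as a limit.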

Compound 4, concentration for half-maximal effect: > 10 uM
Compound 4: no number, only a limit (the forecaster's own chance of this, stated with the estimate: 70%); the middle value is on the limit's open side.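

No new step can be read between compound 3 and compound 4 in this assay, since both results are limits and not numbers: the limit of > 10 uM in this assay, at which 4 of the 4 values shown sit.

The compounds shown leave open whether methyl in place of hydrogen on an oxygen next to a carbonyl group changes the response at all.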